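A Longer Acid Chain at the Assay Limit

The compounds below may be only part of what the source reports. "The series", "measured", "known", "first", "only" and "open" are said of these compounds alone.

In a functional assay on D4 cells (Cricetulus griseus) for inhibition, read by CellTiter-Blue, with a stated time of 96 h, in the presence of a further agent that is not named here (on this read-out higher numbers stand for weaker inhibition and lower numbers for stronger inhibition), compound 3 (`Nc1nc2[nH]c(CCCCCCCC(=O)O)cc2c(=O)[nH]1`) gives > 1000 nM as a limit of the assay, not a number. Compound 2 (`Nc1nc2[nH]c(CCCCCC(=O)O)cc2c(=O)[nH]1`) likewise gives > 1000 nM as a limit. Compound 1 (`Nc1nc2[nH]c(CCCCCCCCC(=O)N[C@@H](CCC(=O)O)C(=O)O)cc2c(=O)[nH]1`) also gives > 1000 nM as a limit.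

Compound 4 (`Nc1nc2[nH]c(CCCCCCCCC(=O)O)cc2c(=O)[nH]1`) carries carboxymethyl in place of carboxy on a saturated chain carbon, seven bonds along the chain from an aromatic carbon. The nearest measured change is a step that the two limits leave unreadable from compound 2 to compound 3 in this assay, and it also lengthens the acid chain. No size can be carried over from it because of the limit of > 1000 nM in this assay, at which 3 of the 3 values shown sit, across the whole series. With no number to build on, compound 4 is expected to stay weak, with no clear gain in inhibition. The expected change is a step that the limit leaves unreadable from compound 3 to compound 4 in this assay, and this is only an estimate. For compound 4 the estimated value is 3000 nM (expected range 1000 nM to 10000 nM) and a further limit is the likeliest report.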

Compound 4, half-maximal inhibitory concentration: > 1000 nM
Compound 4: only a limit was reported; the forecaster's own chance of this, stated with the estimate: 90%; the middle value lies beyond the limit too.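

No step can be read from compound 4 to compound 1, compound 2 or compound 3 in this assay, because all four compounds give only a limit: the limit of > 1000 nM in this assay, at which 4 of the 4 values shown sit.

The compounds shown leave open whether changing the acid chain alters inhibition at all in this assay.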